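Adding a Second Methyl to a Spiro Thiophene Amine

The compounds below may be only part of what the source reports. "The series", "measured", "known", "first", "only" and "open" are said of these compounds alone.

Two compounds share one core and differ only in where a methyl sits on the phenyl ring. In an ADME assay on microsomes from liver (Homo sapiens) for metabolic stability, read by LC-MS, using NADPH, with a stated time of 30 min, tested at 0.5 uM (a higher number here means faster removal of the compound, a lower number slower removal), compound 1 `Cc1ccc(CN2CCC3(CC2)OCCc2sccc23)cc1` gives 22.5 mL/min/g, while compound 2 `Cc1cccc(CN2CCC3(CC2)OCCc2sccc23)c1` gives 5.2 mL/min/g. That is a 4.3-fold lower number from compound 1 to compound 2 (0.64 log units; beyond the scatter), so compound 2 stands as the lower of the two numbers in this assay. Compound 3 `Cc1ccc(CN2CCC3(CC2)OCCc2sccc23)cc1C` keeps the methyl of compound 2 and adds another: methyl in place of hydrogen on an aromatic carbon. For the measured compounds named here, the one measured step bears on this directly, since the new methyl enters at the very position that carried the methyl in compound 1, and moving a methyl between these two positions gave a 4.3-fold lower number from compound 1 to compound 2 (0.64 log units; beyond the scatter). A compound carrying both methyls is therefore expected to move back toward compound 1, and the step from compound 2 to compound 3 in this assay is estimated as a 2.3-fold higher number from compound 2 to compound 3 (0.36 log units; beyond the scatter). Compound 3 is expected to give about 12 mL/min/g, with a range from 5 mL/min/g to 30 mL/min/g.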

Compound 3, intrinsic clearance in a liver preparation (reported as CLH), per the amount of preparation that the assay uses: 18.9 mL/min/g
For compound 3 the middle estimate is 1.6-fold (0.20 log units) below the measured one, and the stated range covers the measured number.
By their numbers in this assay, from the lowest: compound 2; then compounds 3 and 1 (each within the scatter of the next).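

In this assay, a methyl para to a large group goes with the higher number even when the other methyl is already on the ring (a 3.6-fold higher number from compound 2 to compound 3 (0.56 log units; beyond the scatter)). The low number of compound 2 therefore depends on this position staying free of a methyl, and the second methyl does not preserve it. Compound 3 and compound 1 cannot be told apart (a 1.2-fold lower number from compound 1 to compound 3 (0.08 log units; within the scatter)), and no measurement at hand explains the behaviour of this position.

On these data alone, only hydrogen and methyl appear at this position, so it remains open whether a fluorine atom, a chlorine atom or a methoxy group would go with the higher or the lower number. As far as these compounds go, it is also open whether an ethyl group would behave like the methyl.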